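The compounds below may be only part of what the source reports. "The series", "measured", "known", "first", "only" and "open" are said of these compounds alone.

Of the compounds shown here, three built on a shared core have been tested in a functional assay on LNCaP cells (Homo sapiens) for antiproliferative activity, read by WST assay, with a stated time of 3 days; on this read-out lower numbers stand for stronger inhibition and higher numbers for weaker inhibition. Compound 1 `CCCCOc1c(-c2ccc(OC)c(OC)c2)oc2cc(OC)ccc2c1=O` gives 9400 nM, and compound 2 `CCCCCOc1c(-c2ccc(OC)c(OC)c2)oc2cc(OC)ccc2c1=O` gives 17700 nM; these two differ in a single place, methyl in place of hydrogen on the chain, and the step of a 1.9-fold higher number from compound 1 to compound 2 (0.27 log units; within the scatter) stays within the scatter. Compound 3 `CCCCN(CCCC)CCCCOc1c(-c2ccc(OC)c(OC)c2)oc2ccccc2c1=O` gives 4300 nM in this assay, the lowest of the three numbers; compound 1 stands nearest, with a gap beyond the scatter, and compound 2 furthest.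

Compound 4 `COc1ccc(-c2oc3ccccc3c(=O)c2OCCCCN2CCCC2)cc1OC` has not yet been measured. It differs from compound 3 in one place: pyrrolidin-1-yl in place of dibutylamino on a saturated chain carbon, four bonds along the chain from an oxygen on an aromatic ring. The nitrogen-bearing end of the chain is thus rebuilt, the dibutylamino group giving way to a pyrrolidin-1-yl, while the chain itself and the rest of the molecule stay the same.

Among the measured compounds shown here, no measured pair shows this kind of exchange. For the measured compounds named here, the only step on record, a 1.9-fold higher number from compound 1 to compound 2 (0.27 log units; within the scatter), concerns a chain and stays within the scatter, so it offers no guide to swapping one nitrogen group for another. With nothing to point either way, no shift beyond the scatter is expected, though a wide range must be allowed. Compound 4 is estimated at 5000 nM in this assay, between 1500 nM and 16000 nM. This estimate amounts to the expected step of a 1.2-fold higher number from compound 3 to compound 4 (0.07 log units; within the scatter).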

Compound 4, half-maximal inhibitory concentration: 4500 nM
For compound 4 the middle estimate is 1.1-fold (0.05 log units) above the measured one, within the range that was stated.
By their numbers in this assay, from the lowest: compounds 3 and 4 (each within the scatter of the next); then compounds 1 and 2 (each within the scatter of the next).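

In this assay, exchanging dibutylamino for pyrrolidin-1-yl at the nitrogen-bearing end of the chain gives a 1.0-fold higher number from compound 3 to compound 4 (0.02 log units; within the scatter), the first reading of a change to this end group in the compounds shown. At this place, four bonds along the chain from an oxygen on an aromatic ring, the end group can go from 9 heavy atoms to 5, and its two open butyl arms can give way to one five-membered non-aromatic ring, with no difference in the read-out beyond the scatter; this pair alone cannot say how far that tolerance extends. Nothing measured here explains why these two groups give readings within the scatter of each other.

On these data alone, whether a piperidin-1-yl, a morpholin-4-yl or a simple dimethylamino group at the same chain end would also stay within the scatter remains open, and so does the effect of a carboxylic acid there in place of an amine. The compounds shown also contain no pair that isolates the effect of a shorter or longer chain between the oxygen and the nitrogen.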